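Ester in place of a secondary amide on the shared core

This account rests on a few compounds, and the source may have more. Where it says the series, first, only, none or still open, it means among the compounds named here.

Measured so far in an assay on cells for agonist activity at vitamin D3 receptor (Homo sapiens), with a stated time of 96 h; a lower number here means that less compound is needed, a higher number that more compound is needed for the effect:
Compound 1, `CCn1c(C(=O)NCCN(C)C)ccc1C(CC)(CC)c1ccc(OCCC(O)(CC)CC)c(C)c1`, gives 82 nM.
Compound 2, `CCn1c(C(=O)NCC#N)ccc1C(CC)(CC)c1ccc(OCCC(O)(CC)CC)c(C)c1`, gives 1080 nM.
Compound 3, `C=CCN(C)C(=O)c1ccc(C(CC)(CC)c2ccc(OCCC(O)(CC)CC)c(C)c2)n1CC`, gives > 10000 nM, which is a limit of the assay rather than a number.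

Compound 2 holds the higher of the two numbers actually measured; its nearest neighbour is compound 1, the change being a 13-fold higher number from compound 1 to compound 2 (1.12 log units; beyond the scatter). The third value, that of compound 3, sits at the limit of > 10000 nM in this assay, at which 1 of the 3 values shown sits.

Compound 4, `C#CCCOC(=O)c1ccc(C(CC)(CC)c2ccc(OCCC(O)(CC)CC)c(C)c2)n1CC`, has not yet been measured. It differs from compound 2 in one place: (but-3-yn-1-yl)oxy in place of (cyanomethyl)amino on a carbonyl carbon. The group that leaves carries the one hydrogen-bond donor of that side chain; the group that enters brings none.

Among the measured compounds shown here, one measured step bears directly on this change. Replacing the side chain on the carbonyl carbon of compound 2 with a group that likewise carries no hydrogen-bond donor gave an at least 9.2-fold higher number from compound 2 to compound 3 (0.96 log units; beyond the scatter). The step of an at least 120-fold higher number from compound 1 to compound 3 (2.08 log units; beyond the scatter) points the same way. A worsening beyond the scatter is therefore expected for compound 4 in this assay, and a reading at the limit is a real possibility.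

Compound 4 is thus expected to show a step of a 4.6-fold higher number from compound 2 to compound 4 (0.67 log units; beyond the scatter).
Compound 4 is estimated at 5000 nM, with a likely range from 1500 nM to 20000 nM.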

Compound 4, half-maximal effective concentration: 6030 nM
The estimate for compound 4 lay 1.2-fold (0.08 log units) below the measured number; measured number inside the range.
By their numbers in this assay, from the lowest: compound 1; then compound 2; then compound 4. At a limit, above all of these: compound 3.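

In this assay, replacing the (cyanomethyl)amino side chain with an ester side chain that has no hydrogen-bond donor, while keeping a triple bond, gives a measurable but clearly worse result: a 5.6-fold higher number from compound 2 to compound 4 (0.75 log units; beyond the scatter). The distance from the amide ending in a dimethylamino group is larger, at a 74-fold higher number from compound 1 to compound 4 (1.87 log units; beyond the scatter). Among these four compounds, the two that keep the amide hydrogen have the two lowest numbers, and none goes against this pattern, although four compounds are too few to show that the hydrogen itself is what matters; the step of an at least 1.6-fold lower number from compound 3 to compound 4 (0.21 log units; that floor lies within the scatter) does not set compound 4 apart from compound 3, whose reading is a limit: the limit of > 10000 nM in this assay, at which 1 of the 4 values shown sits.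

The change from compound 2 to compound 4 alters both the atom bound to the carbonyl carbon and the chain beyond it, so the effect of each remains unresolved. A cyanomethyl ester would test the oxygen with the chain of compound 2 kept in place, while a 2-(dimethylamino)ethyl ester would ask whether the terminal amine of compound 1 can recover activity without the amide hydrogen.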